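The source may hold more compounds than are shown below. What is called first, only, known or untested is meant among the compounds shown, and "the series" means these compounds.

In a functional assay on SK-MEL-2 cells (Homo sapiens) for cytotoxicity, read by sulforhodamine B assay, with a stated time of 48 h (on this read-out lower numbers stand for stronger inhibition of growth and higher numbers for weaker inhibition of growth), compound 2 `ClCc1cccc(Cn2cnc3c(Cl)ncnc32)c1` gives 51300 nM. Compound 1 `ClCc1ccc(Cn2cnc3c(Cl)ncnc32)cc1` gives > 100000 nM in this assay, and that figure is a limit of the assay rather than a number: the limit of > 100000 nM in this assay, at which 1 of the 2 values shown sits. Among the compounds with values here, of the two values shown, compound 2 therefore carries the only actual number. Compound 3 `ClCc1cccc(Cn2cnc3c(Cl)nc(Cl)nc32)c1` has not yet been measured. It differs from compound 2 by chloro in place of hydrogen on an aromatic carbon. Within the data shown here, no step from one measured compound to another is available to show how large such a change can be in this assay, so no shift beyond the usual scatter is expected, in either direction. Compound 3 is expected to give about 40000 nM, within a likely range from 15000 nM to 100000 nM. The estimated step from compound 2 to compound 3 is a 1.3-fold lower number from compound 2 to compound 3 (0.11 log units; within the scatter).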

Compound 3, concentration for total growth inhibition: 4460 nM
Beside the measured number, compound 3's estimate is 9.0-fold (0.95 log units) above it; measured number below the stated range.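

The earlier compounds shown here offered no step at all in this assay, so nothing yet showed how much a single change could matter here. Chloro in place of hydrogen, on an aromatic carbon between two ring nitrogen atoms, now gives a 12-fold lower number from compound 2 to compound 3 (1.06 log units; beyond the scatter) and so shows that this one added heavy atom can move the number well past ordinary variation between repeats. Nothing measured here accounts for the size of this step.

The compounds shown leave open whether another group on this same carbon, such as an amine, a methoxy group or a longer chain, would give a step of similar size. From the compounds shown here alone, whether the same chloro would act alike on the core of compound 1 also stays open, since its > 100000 nM is a limit and not a number.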